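The compounds below may be only part of what the source reports. "The series", "measured", "known", "first", "only" and "open" are said of these compounds alone.

Measured compounds:
compound 1 `C[C@H](NC(=O)CN(c1nc(Cl)nc2[nH]cnc12)C1CC1)C(=O)OCc1ccccc1` — 23%
compound 2 `CSCC[C@H](NC(=O)CN(c1nc(Cl)nc2[nH]cnc12)C1CC1)C(=O)O` — 4.14%

Both numbers come from a functional assay on the whole organism (Tail, strain ICR) with Mus musculus as the target, in the tail flick test, with a stated time of 150 min, at a dose of 25 umol/kg by the oral route; on this read-out lower numbers stand for a weaker effect and higher numbers for a stronger effect at the one dose given. In that test compound 1 gives 23%, and compound 2 gives 4.14%. Compound 2 stands lowest of the two numbers; its nearest neighbour, compound 1, lies higher by a margin that is beyond the usual scatter. Within the data shown here, the two measured compounds differ in more than one place, so no single step can be drawn between them, and all they show is the two values side by side.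

Compound 3 `C[C@H](NC(=O)CN(c1nc(Cl)nc2[nH]cnc12)C1CC1)C(=O)O` has not yet been tested. It is reached from compound 2 by one change: hydrogen in place of (methylsulfanyl)methyl on a saturated chain carbon, two bonds along the chain from an amide-type nitrogen and a carbonyl carbon. Among the measured compounds shown here, no measured pair isolates this change, so there is nothing to lean on beyond the low value of compound 2 itself. Since compound 2 gives 4.14%, the estimated step of a number 3.9 percentage points higher from compound 2 to compound 3 (within the scatter) is expected to be small, upward if at all, and within the scatter. Compound 3 is therefore expected to give about 8%, with a range from 0% to 22%.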

Compound 3, a percentage reported as activity, at one dose (the size of the read-out at that dose, not a potency): 14.7%
Estimate against measurement, compound 3: 6.7 percentage points below, within the range that was stated.
By their numbers in this assay, from the lowest: compound 2; then compounds 3 and 1 (each within the scatter of the next).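

In this assay, among these compounds, the step of a number 10.6 percentage points higher from compound 2 to compound 3 (beyond the scatter) gives the first reading at the saturated chain carbon, two bonds along the chain from an amide-type nitrogen and a carbonyl carbon: with hydrogen in place of (methylsulfanyl)methyl, the effect rises modestly, so at this dose the larger group brings no gain over hydrogen. Compound 3 also links the series to the benzyl compound, and the step of a number 8.3 percentage points lower from compound 1 to compound 3 (within the scatter) shows that, with hydrogen in place of benzyl on an oxygen next to a carbonyl group, the two compounds cannot be told apart in this assay. Nothing measured here speaks to why either step comes out as it does.

The compounds shown leave open whether the effect of removing (methylsulfanyl)methyl would hold with benzyl on the oxygen, since each of the two changes is seen only on its own. They also leave open how the chain carbon would read with a hydroxymethyl group, an isopropyl group or a longer chain without sulfur, and whether an amide in place of the carboxylic acid would fall with compound 3 or apart from it.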